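This account rests on a few compounds, and the source may have more. Where it says the series, first, only, none or still open, it means among the compounds named here.

Compound 1 `Cc1cn([C@@H]2O[C@H](CO[Si](C)(C)C(C)(C)C)[C@@]3(OS(=O)(=O)C=C3NC(=O)c3ccccc3)[C@H]2O[Si](C)(C)C(C)(C)C)c(=O)n(C)c1=O`: >= 3200 nM
Compound 2 `Cc1cn([C@@H]2O[C@H](CO[Si](C)(C)C(C)(C)C)[C@@]3(OS(=O)(=O)C=C3NC(N)=O)[C@H]2O[Si](C)(C)C(C)(C)C)c(=O)n(C)c1=O`: 16000 nM
Compound 3 `COC(=O)CC(=O)NC1=CS(=O)(=O)O[C@@]12[C@@H](CO[Si](C)(C)C(C)(C)C)O[C@@H](n1cc(C)c(=O)n(C)c1=O)[C@@H]2O[Si](C)(C)C(C)(C)C`: 400000 nM

In a functional assay on HEL cells (Homo sapiens) for cytotoxicity, read by microscopy (on this read-out higher numbers stand for lower toxicity in this test and lower numbers for higher toxicity in this test), compound 3 stands highest of the two numbers that were read; its nearest neighbour is compound 2, and the step between them is a 25-fold higher number from compound 2 to compound 3 (1.40 log units; beyond the scatter). The value of compound 1 is a limit of the assay the limit of >= 3200 nM in this assay, at which 1 of the 3 values shown sits, and not a number. Compound 4 `CCOC(=O)CNC(=O)NC1=CS(=O)(=O)O[C@@]12[C@@H](CO[Si](C)(C)C(C)(C)C)O[C@@H](n1cc(C)c(=O)n(C)c1=O)[C@@H]2O[Si](C)(C)C(C)(C)C` differs from compound 3 in one place: ((ethoxycarbonyl)methyl)amino in place of (methoxycarbonyl)methyl on a carbonyl carbon. Among the measured compounds shown here, the only readable step concerns the same carbonyl carbon, where amino gave way to (methoxycarbonyl)methyl with a 25-fold higher number from compound 2 to compound 3 (1.40 log units; beyond the scatter). Since compound 4 again places an amino group on that carbonyl carbon, as compound 2 does, compound 4 is expected to give a lower number than compound 3, with a step of about a 4.0-fold lower number from compound 3 to compound 4 (0.60 log units; beyond the scatter). Compound 4 is therefore estimated at 100000 nM, between 25000 nM and 400000 nM.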

Compound 4, minimum cytotoxic concentration: 16000 nM
Compound 4: middle estimate off by 6.3-fold (0.80 log units), on the high side, outside the stated range (below it).
By their numbers in this assay, from the lowest: compounds 2 and 4 (each within the scatter of the next); then compound 3.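

In this assay, ((ethoxycarbonyl)methyl)amino in place of (methoxycarbonyl)methyl on the carbonyl carbon gives a 25-fold lower number from compound 3 to compound 4 (1.40 log units; beyond the scatter), while (ethoxycarbonyl)methyl in place of hydrogen on the amide-type nitrogen gives no change at the digits printed from compound 2 to compound 4 (within the scatter). Among the readable values, compound 2 and compound 4 both carry nitrogen on this carbonyl carbon and lie within the scatter of each other, whereas compound 3, with carbon there, stands apart. The steps from compound 1 cannot be read, as its value is a limit: the limit of >= 3200 nM in this assay, at which 1 of the 4 values shown sits.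

From the compounds shown here alone, whether a plain methyl group on the carbonyl carbon would match compound 3 remains open. So does whether a carboxylic acid in place of the ester of compound 4 would alter its number.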